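The source may hold more compounds than are shown below. What is called first, only, known or untested is meant among the compounds shown, and "the series" means these compounds.

Compound 1 `COc1cc2c(cc1OC)C(CC(=O)O)CC2` gives 26.7% in a functional assay on the whole organism (strain Wistar) for inhibition, with Rattus norvegicus as the target, read by paw edema, with stated times of 60 min and 24 h, at a dose of 100 mg/kg by the oral route; on this read-out lower numbers stand for less inhibition and higher numbers for more inhibition at the one dose given (going by the name of the read-out).
Compound 2 `CNC(=O)CC1CCc2cc(OC)c(OC)cc21` gives 33.3%.
Compound 3 `COc1cc2c(cc1OC)C(CC(=O)NC(C)(C)C)CC2` gives 40%.

Compound 3 holds the highest of the three numbers, though a number 6.7 percentage points higher from compound 2 to compound 3 (within the scatter) lies within the scatter, while a number 13.3 percentage points higher from compound 1 to compound 3 (beyond the scatter) lies beyond it. Compound 4 `COc1cc2c(cc1OC)C(CC(=O)NCc1ccccc1)CC2` differs from compound 3 by benzyl in place of tert-butyl on an amide-type nitrogen. Within the data shown here, the only measured step at that same place on the amide-type nitrogen is a number 6.7 percentage points higher from compound 2 to compound 3 (within the scatter), within the scatter; the other steps, a number 6.6 percentage points higher from compound 1 to compound 2 (within the scatter) and a number 13.3 percentage points higher from compound 1 to compound 3 (beyond the scatter), swap a hydroxy for an amine and do not touch a group already on the nitrogen. With so small a precedent, no step beyond the scatter is expected, only a number 2 percentage points higher from compound 3 to compound 4 (within the scatter). Compound 4 is therefore estimated at 42%, within 27% to 57%.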

Compound 4, a percentage reported as inhibition, in the whole organism at one dose (the size of the read-out at that dose, not a potency): 43.3%
Compound 4: middle estimate off by 1.3 percentage points, on the low side; measured number inside the range.
By their numbers in this assay, from the lowest: compounds 1, 2, 3 and 4 (each within the scatter of the next, the first and the last beyond it).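

On the amide-type nitrogen, benzyl in place of tert-butyl brings in a six-membered aromatic ring, yet this assay shows only a number 3.3 percentage points higher from compound 3 to compound 4 (within the scatter), and the comparison with the methyl amide gives a number 10 percentage points higher from compound 2 to compound 4 (within the scatter). Only the change from the acid separates clearly, with a number 16.6 percentage points higher from compound 1 to compound 4 (beyond the scatter), so among these amides the group on nitrogen cannot be told apart. Nothing measured here explains these numbers.

From the compounds shown here alone, a phenylethyl group, with a longer chain before the ring, remains open, as does a plain amino group on the carbonyl carbon. Going by these compounds, with a single dose, potency also remains open.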